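Benzyl in place of fluorophenoxy on the side chain

This account rests on a few compounds, and the source may have more. Where it says the series, first, only, none or still open, it means among the compounds named here.

Compound 3, `CC(C)(Oc1ccccc1F)C1OCC(C/C=C\CCC(=O)O)C(c2cccnc2)O1`, gives 45 nM in an assay for inhibition of Thromboxane-A synthase (Homo sapiens), using microsomes; a higher number here means a weaker inhibitor, a lower number a stronger inhibitor. That number is the second highest of the three available, yet compound 2, `O=C(O)CC/C=C\CC1COC(c2ccc(C(F)(F)F)cc2)OC1c1cccnc1`, with 44 nM, and compound 1, `N#Cc1ccccc1C1OCC(C/C=C\CCC(=O)O)C(c2cccnc2)O1`, with 54 nM, both lie within the scatter of compound 3, so the three compounds cannot be told apart on this assay. Compound 4, `CC(C)(Cc1ccccc1)C1OCC(C/C=C\CCC(=O)O)C(c2cccnc2)O1`, differs from compound 3 in one place: benzyl in place of 2-fluorophenoxy on a saturated chain carbon bound to two saturated chain carbons and a saturated ring carbon. Within the data shown here, the one measured step between single-point variants, a 1.2-fold lower number from compound 1 to compound 2 (0.09 log units; within the scatter), exchanged one aromatic group for another on the saturated ring carbon and moved the number by less than the scatter. Among the measured compounds shown here, that step does not touch the same position, and no measured pair shows what replacing an oxygen-linked aromatic group by a carbon-linked one on the saturated chain carbon does. The closest evidence is that swapping aromatic groups on the shared core has so far left this assay nearly unchanged, so compound 4 is expected to behave much like compound 3, with a step of a 1.2-fold higher number from compound 3 to compound 4 (0.09 log units; within the scatter) that stays inside the scatter. Compound 4 is therefore estimated at 55 nM, with a range from 25 nM to 130 nM.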

Compound 4, half-maximal inhibitory concentration: 12 nM
Compound 4: middle estimate off by 4.6-fold (0.66 log units), on the high side; the whole stated range lies above it.
By their numbers in this assay, from the lowest: compound 4; then compounds 2, 3 and 1 (each within the scatter of the next).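

In this assay the exchange of 2-fluorophenoxy for benzyl on the saturated chain carbon produces a step beyond the scatter (a 3.8-fold lower number from compound 3 to compound 4 (0.57 log units; beyond the scatter)), so the number does respond to this change, whereas the exchange of 2-cyanophenyl for 4-(trifluoromethyl)phenyl on the saturated ring carbon stayed within the scatter. The 1-benzyl-1-methylethyl group also stands clear of 4-(trifluoromethyl)phenyl (a 3.7-fold lower number from compound 2 to compound 4 (0.56 log units; beyond the scatter)) and of 2-cyanophenyl (a 4.5-fold lower number from compound 1 to compound 4 (0.65 log units; beyond the scatter)), which makes compound 4 the strongest inhibitor of the four. No measurement at hand accounts for the lower number that comes with benzyl.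

The compounds shown do not separate the loss of the oxygen from the loss of the fluorine, and a plain phenoxy or a 2-fluorobenzyl group on the same carbon would be needed to tell those two apart. As far as these compounds go, it also remains open whether a longer chain such as phenethyl in place of benzyl, or an amine on its aromatic ring, would take the number lower still or raise it again.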